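Aryl swap on the shared core: compound 1 to compound 3

This account rests on a few compounds, and the source may have more. Where it says the series, first, only, none or still open, it means among the compounds named here.

Compound 1 `CCOC(=O)c1sc(NC(=O)Cn2cc(-c3cccs3)nn2)nc1C` carries the lowest of the two numbers recorded in a functional assay on BMDM cells (Mus musculus, strain C57BL/6) for inhibition, with a stated time of 2 days; a higher number here means a weaker inhibitor, a lower number a stronger inhibitor; in this assay compound 1 gives 20 nM. Compound 2 `Cc1cc(NC(=O)Cn2cc(-c3ccc(Cl)cc3)nn2)no1`, built on a different core, gives 1910 nM in this assay, a far higher number that lies well beyond the scatter. Compound 3 `CCOC(=O)c1sc(NC(=O)Cn2cc(-c3ccc(F)cc3)nn2)nc1C` differs from compound 1 in one place: 4-fluorophenyl in place of thiophen-2-yl on an aromatic carbon. For the measured compounds named here, no step between measured compounds covers this change, so the expectation rests on compound 1 alone; a small step upward, within or just beyond the scatter, is expected, a 2.0-fold higher number from compound 1 to compound 3 (0.30 log units; within the scatter). For compound 3 the estimate in this assay is 40 nM, with a range from 10 nM to 160 nM.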

Compound 3, half-maximal inhibitory concentration: 660 nM
Compound 3: middle estimate off by 17-fold (1.22 log units), on the low side; the whole stated range lies below it.
By their numbers in this assay, from the lowest: compound 1; then compound 3; then compound 2.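

In this assay, 4-fluorophenyl in place of thiophen-2-yl on the shared core gives a 33-fold higher number from compound 1 to compound 3 (1.52 log units; beyond the scatter). This single change shows that the number is highly sensitive to the aromatic group at this position, which the two earlier compounds, differing in more than one place, could not show. Nothing available here bears on what lies behind the step. Going by these compounds, it remains open whether plain phenyl or furan-2-yl at this position would stand nearer compound 1 or compound 3. Whether the fluorine or the six-membered ring carries the step also remains unresolved.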